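Fluorine in Place of Methyl on the Outer Ring

This account rests on a few compounds, and the source may have more. Where it says the series, first, only, none or still open, it means among the compounds named here.

Compound 1 `CC(C)C[C@H](N)CN(C(=O)[C@@H]1C[C@H]1c1ccccc1)c1ccc(-c2ccccc2)cc1`: 880 nM in a functional assay for agonist activity at G protein-coupled receptor 88 (Homo sapiens), read by HTRF and cAMP accumulation; on this read-out lower numbers stand for an effect already at smaller amounts and higher numbers for an effect only at larger amounts of compound
Compound 2 `Cc1cccc(-c2ccc(N(C[C@@H](N)CC(C)C)C(=O)[C@@H]3C[C@H]3c3ccccc3)cc2)c1`: 1200 nM in this assay

Compound 2 and compound 1 cannot be told apart on these numbers, since a 1.4-fold higher number from compound 1 to compound 2 (0.13 log units; within the scatter) is within the scatter. Compound 3 `CC(C)C[C@H](N)CN(C(=O)[C@@H]1C[C@H]1c1ccccc1)c1ccc(-c2ccccc2F)cc1` differs from compound 2 by 2-fluorophenyl in place of 3-methylphenyl on an aromatic carbon. Within the data shown here, the one measured step that bears on this ring, a 1.4-fold higher number from compound 1 to compound 2 (0.13 log units; within the scatter), changed it without moving the read-out beyond the scatter, so for compound 3 no step beyond the scatter is expected, a 1.2-fold lower number from compound 2 to compound 3 (0.08 log units; within the scatter). Compound 3 is therefore estimated at 1000 nM, with a range from 400 nM to 2500 nM.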

Compound 3, half-maximal effective concentration: 1600 nM
Compound 3: middle estimate off by 1.6-fold (0.20 log units), on the low side; measured number inside the range.
By their numbers in this assay, from the lowest: compounds 1, 2 and 3 (each within the scatter of the next).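

On the outer ring, fluoro in place of hydrogen gives a 1.8-fold higher number from compound 1 to compound 3 (0.26 log units; within the scatter), and 2-fluorophenyl in place of 3-methylphenyl gives a 1.3-fold higher number from compound 2 to compound 3 (0.12 log units; within the scatter). The ring has now carried two different groups, a methyl and a fluoro, and neither step leaves the scatter in this assay, so this ring has tolerated both changes without a distinguishable shift in the read-out. Nothing measured here offers an explanation for these steps. As far as these compounds go, whether an amine or a carboxylic acid on this ring would move the number beyond the scatter remains open. So does whether fluoro and methyl would differ if they stood at the same place on the ring.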